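This account rests on a few compounds, and the source may have more. Where it says the series, first, only, none or still open, it means among the compounds named here.

Three compounds were examined in a functional assay on U-87MG ATCC cells for antiproliferative activity against U-87 MG (Homo sapiens), read by MTT assay, with a stated time of 48 h, tested at 10 uM; on this read-out lower numbers stand for a stronger effect and higher numbers for a weaker effect at the one concentration tested. Compound 1 `COc1ccc(-c2nc(C)c(C(=O)CSc3nc(N)c(C#N)c(-c4ccccc4)n3)s2)cc1` gives 57.8% in this assay. Compound 2 `COc1ccc(-c2nc(C)c(C(=O)CSc3nc(-c4cccc(OC)c4)c(C#N)c(=O)[nH]3)s2)cc1` gives 66.7%, and compound 3 `COc1cccc(-c2nc(SCC(=O)c3sc(-c4ccccc4)nc3C)[nH]c(=O)c2C#N)c1` gives 90.2%. Compounds 2 and 3 share one core and differ in a single place: methoxy in place of hydrogen on an aromatic carbon. That change produced a number 23.5 percentage points lower from compound 3 to compound 2 (beyond the scatter), a modest step toward a stronger effect. Compound 1 has a different core; the difference between the two cores is not broken down here, and its number and that of compound 2 lie within the scatter of each other.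

Compound 4 `COc1ccc(-c2nc(C)c(C(=O)CSc3nc(N)c(C#N)c(-c4ccc(OC)cc4)n3)s2)cc1` has not been measured yet. It is built from compound 1 by the same change: methoxy in place of hydrogen on an aromatic carbon. The surroundings of the place are described in the same words for both pairs, so this is the same change made on a different core. For the measured compounds named here, for compound 4 a step in the same direction but somewhat smaller is expected, a number 13.8 percentage points lower from compound 1 to compound 4 (beyond the scatter), because the same change gave a number 23.5 percentage points lower from compound 3 to compound 2 (beyond the scatter) on the other core, and only that one example exists. Compound 4 is therefore estimated at 44%, with a likely range from 28% to 62%.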

Compound 4, a percentage reported as activity, at one concentration (the size of the read-out at that concentration, not a potency): 28.7%
Compound 4: middle estimate off by 15.3 percentage points, on the high side, within the range that was stated.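

Methoxy in place of hydrogen gave a number 29.1 percentage points lower from compound 1 to compound 4 (beyond the scatter) in this assay, and this agrees in direction and size with the step seen on the other core: the same change on two cores in this assay, a number 23.5 percentage points lower (beyond the scatter) from compound 3 to compound 2 and a number 29.1 percentage points lower (beyond the scatter) from compound 1 to compound 4, 5.6 percentage points apart, within the scatter of two such steps
Within these compounds, then, the change carried over from one core to the other, and its size on one core was a fair guide to its size on the other. For the compounds shown here, the result rests on only two pairs, each read at a single concentration, so it does not show that the change would behave the same way on a further core, and it does not explain why the number falls.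

At the place that changed, the compounds shown carry only hydrogen or methoxy, so it remains open how a fluorine, a hydroxyl, an ethoxy or an amine would compare there. Going by these compounds, it also remains open whether methoxy would give a similar step on another carbon of that six-membered ring.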